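Piperidin-1-yl replacing (trifluoromethyl)sulfanyl in compound 3

The source may report more compounds than this note shows. Statements on the series, on what has been measured and on what is new or still open speak of the compounds shown alone.

- compound 1 `Cc1c(-c2ccc(Cc3ccc(C(C)(O)C(F)(F)F)cc3)cc2)[nH]c2cccc(F)c2c1=O`: > 2500 nM
- compound 2 `CN=S(=O)(c1ccc(Cc2ccc(-c3[nH]c4cccc(F)c4c(=O)c3C)cc2)cc1)C(F)(F)F`: > 10000 nM
- compound 3 `Cc1c(-c2ccc(Oc3ccc(SC(F)(F)F)cc3)c(F)c2)[nH]c2cccc(F)c2c1=O`: > 10000 nM

All three results in an ADME assay on Huh7.5.1 cells (Homo sapiens) for cytotoxicity, read by WST assay, with a stated time of 48 h (a higher number here means that more compound is tolerated, a lower number that less compound is tolerated), are limits and not numbers: the limit of > 10000 nM in this assay, at which 2 of the 3 values shown sit, and (the limit of > 2500 nM in this assay, at which 1 of the 3 values shown sits). Compound 3 gives > 10000 nM, which is a limit.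

Compound 4 `Cc1c(-c2ccc(Oc3ccc(N4CCCCC4)cc3)c(F)c2)[nH]c2cccc(F)c2c1=O` carries piperidin-1-yl in place of (trifluoromethyl)sulfanyl on an aromatic carbon, para to a large group: piperidin-1-yl in place of (trifluoromethyl)sulfanyl on an aromatic carbon.

Among the compounds with values here, the only measured step is a step that the two limits leave unreadable from compound 1 to compound 2. It has no readable size to carry over, and it lies in another group. No change beyond the scatter is therefore expected, and the estimated step is a number no higher from compound 3 to compound 4 (the limit leaves the size open). For compound 4 the expected value is 10000 nM, with an estimated range of 3000 nM to 30000 nM.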

Compound 4, half-maximal cytotoxic concentration: > 10000 nM
Compound 4 gave a limit, no number; the forecaster's own chance of this, stated with the estimate: 65%; the middle value lies on the limit itself.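

Compound 3 and compound 4 each give a limit and not a number, so no step can be read between them. The compounds shown leave open whether piperidin-1-yl in place of (trifluoromethyl)sulfanyl changes the half-maximal cytotoxic concentration at all.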